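Adding One Methyl Group to Compound 2

This account rests on a few compounds, and the source may have more. Where it says the series, first, only, none or still open, it means among the compounds named here.

In a functional assay on J774 cells (Mus musculus) for cytotoxicity, read by resazurin assay (a lower number here means a stronger inhibitor, a higher number a weaker inhibitor), compound 1 (`OCCCCCC(O)c1ccc(-c2ccc(O)cc2)cc1`) gives 15000 nM and compound 2 (`O=C(CCCCCO)c1ccc(-c2ccccc2)cc1`) gives 22000 nM. Within the data shown here, these two values lie within the usual scatter of each other, so compound 2 stands level with the only other measured compound. Compound 3 (`Cc1cccc(-c2ccc(C(=O)CCCCCO)cc2)c1`) carries a methyl in place of hydrogen on an aromatic carbon of compound 2, meta to a large group (methyl in place of hydrogen on an aromatic carbon). Among the measured compounds shown here, no measured pair shows such a change, so no step beyond the scatter is expected in this assay, and the expected step is a 1.2-fold lower number from compound 2 to compound 3 (0.09 log units; within the scatter). Compound 3 is estimated at 18000 nM, within an expected range of 8000 nM to 40000 nM.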

Compound 3, half-maximal inhibitory concentration: 100000 nM
Compound 3: the middle estimate sits 5.6-fold (0.74 log units) below what was measured, and the stated range ends below it.
By their numbers in this assay, from the lowest: compounds 1 and 2 (each within the scatter of the next); then compound 3.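

In this assay the swap of hydrogen for methyl, on an aromatic carbon meta to a large group, gives a 4.5-fold higher number from compound 2 to compound 3 (0.66 log units; beyond the scatter) and makes compound 3 the weaker inhibitor of this pair. Among these compounds, this is the first single-place change with a measured step here, and it shows that one added carbon at this position can move the number beyond the scatter. Nothing at hand explains why the number moves.

On these data alone, whether an ethyl or a methoxy group at this position would move the number further remains open. So does whether a methyl elsewhere on this ring would have the same effect.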